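The source may report more compounds than this note shows. Statements on the series, on what has been measured and on what is new or still open speak of the compounds shown alone.

Of the compounds shown here, two sharing one core have been measured so far in a functional assay on NCI-H460 cells (Homo sapiens) for inhibition, read by sulforhodamine B assay, with a stated time of 48 h; on this read-out lower numbers stand for stronger inhibition of growth and higher numbers for weaker inhibition of growth. Compound 1 (`O=C(Cc1csc2nc(-c3ccc(Br)cc3)cn12)N/N=C/c1ccccc1`) gives > 100000 nM, which is a limit and not a number. Compound 2 (`COc1cccc(OC)c1/C=N/NC(=O)Cc1csc2nc(-c3ccc(Br)cc3)cn12`) gives > 100000 nM, which is also a limit. Compound 2 therefore has no exact standing, and the whole record so far is the limit of > 100000 nM in this assay, at which 2 of the 2 values shown sit.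

The next compound, compound 3 (`O=C(Cc1csc2nc(-c3ccc(Br)cc3)cn12)N/N=C/c1ccc(Cl)cc1Cl`), carries 2,4-dichlorophenyl in place of 2,6-dimethoxyphenyl on a carbon with a double bond to nitrogen. Going by the values given here, the only measured step bearing on this change is a step that the two limits leave unreadable from compound 1 to compound 2, so it offers neither a size nor a direction to carry over. Neither compound 1 nor compound 2 has yet given a number in this assay, and another limit would be the likeliest result. The expected change, small and towards stronger inhibition of growth if it can be read at all, is an at least 1.1-fold lower number from compound 2 to compound 3 (0.04 log units; that floor lies within the scatter). The estimate for compound 3 is 90000 nM, with an expected range from 30000 nM to 100000 nM.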

Compound 3, concentration for total growth inhibition: > 100000 nM
Compound 3 ended at the assay's limit; the forecaster's own chance of this, stated with the estimate: 65%; middle value at least 1.1-fold (0.04 log units) from the limit.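

In this assay, going by these compounds alone, no step among compound 1, compound 2 and compound 3 can be read, because all three compounds sit at one limit, which is not a number: the limit of > 100000 nM in this assay, at which 3 of the 3 values shown sit. The compounds shown leave open whether phenyl, 2,6-dimethoxyphenyl and 2,4-dichlorophenyl on a carbon with a double bond to nitrogen differ at all in this assay.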